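From Pyridine to Pyrimidine on a Shared Core

This account rests on a few compounds, and the source may have more. Where it says the series, first, only, none or still open, it means among the compounds named here.

Three compounds have been measured in an assay on a protein complex for inhibition of ubiquitin carboxyl-terminal hydrolase 1/WD repeat-containing protein 48 (Homo sapiens), read by fluorescence; a higher number here means a weaker inhibitor, a lower number a stronger inhibitor:

Compound 1 `COc1ccc(CNc2nc(-c3ccccc3C(F)(F)F)nc3ccccc23)cc1` gives 6200 nM.
Compound 2 `FC(F)(F)c1ccc(CNc2nc(-c3ccccc3C(F)(F)F)nc3ccccc23)cc1` gives 8900 nM.
Compound 3 `FC(F)(F)c1ccccc1-c1nc(NCc2ccc(-c3ccncc3)cc2)c2ccccc2n1` gives 1900 nM.

Compound 3 stands lowest of the three, and so is the strongest inhibitor here: the step of a 3.3-fold lower number from compound 1 to compound 3 (0.51 log units; beyond the scatter) and the step of a 4.7-fold lower number from compound 2 to compound 3 (0.67 log units; beyond the scatter) both lie beyond the scatter, whereas the step of a 1.4-fold higher number from compound 1 to compound 2 (0.16 log units; within the scatter) does not. Compound 4 `FC(F)(F)c1ccccc1-c1nc(NCc2ccc(-c3cncnc3)cc2)c2ccccc2n1` is the next compound, and it differs from compound 3 in one place: pyrimidin-5-yl in place of pyridin-4-yl on an aromatic carbon. Within the data shown here, no measured step swaps one heteroaromatic ring for another, so the two steps that bear on it are those leading to compound 3, which show that a six-membered aromatic ring with a nitrogen at this position gave modest gains over methoxy and trifluoromethyl. Since pyrimidin-5-yl keeps such a ring in place, the expected step in this assay is small, likely within the scatter, a 1.3-fold higher number from compound 3 to compound 4 (0.12 log units; within the scatter). Compound 4 is therefore estimated at 2500 nM, in the range 900 nM to 7000 nM.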

Compound 4, half-maximal inhibitory concentration: 3000 nM
Compound 4: the middle estimate sits 1.2-fold (0.08 log units) below what was measured; measured number inside the range.
By their numbers in this assay, from the lowest: compounds 3 and 4 (each within the scatter of the next); then compounds 1 and 2 (each within the scatter of the next).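

Pyrimidin-5-yl, with its second ring nitrogen, cannot be told apart from pyridin-4-yl at this position (a 1.6-fold higher number from compound 3 to compound 4 (0.20 log units; within the scatter)), so the extra hetero atom neither clearly helps nor clearly harms. The advantage over the non-ring groups also holds with this new ring: the steps to pyrimidin-5-yl are beyond the scatter, both from trifluoromethyl (a 3.0-fold lower number from compound 2 to compound 4 (0.47 log units; beyond the scatter)) and from methoxy (a 2.1-fold lower number from compound 1 to compound 4 (0.32 log units; beyond the scatter)), so two different nitrogen-containing aromatic rings now stand ahead of both groups. Nothing shown here offers an explanation for these numbers.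

From the compounds shown here alone, whether the ring nitrogens matter at all remains open, and a plain phenyl ring at this place would test that. A saturated amine such as morpholine would ask whether the ring must be aromatic, while pyridin-3-yl would ask whether the location of the nitrogen within the ring counts.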